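The source may hold more compounds than are shown below. What is called first, only, known or untested is meant among the compounds shown, and "the series" means these compounds.

Measured so far:
Compound 1, `CC(C)(C)OC(=O)Nc1ncc(C(Oc2ccc(OCc3ccccc3)cc2)c2ccc(Cl)cc2)s1`, in an ADME assay on HepG2 2.2.15 cells (Homo sapiens) for cytotoxicity (on this read-out lower numbers stand for higher toxicity in this test and higher numbers for lower toxicity in this test), gives > 50000 nM.
Compound 2, `O=C(Nc1ncc(C(Oc2ccc3cc(Br)ccc3c2)c2ccc(Cl)cc2)s1)c1cccs1`, in this assay gives "not toxic" (no number reported).

The reading for compound 1 is a limit of the test, not a measured number. The reading for compound 2 is likewise a limit, reported without any figure. Both sit at the upper edge of what this test reports: the limit of > 50000 nM in this assay, at which 1 of the 2 values shown sits, and compound 2 stands alongside it with no number of its own.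

Compound 3, `O=C(Nc1ncc(C(Oc2ccc3cc(Br)ccc3c2)c2ccc(Cl)cc2)s1)C1CC1`, has not yet been tested. It differs from compound 2 in one place: cyclopropyl in place of thiophen-2-yl on a carbonyl carbon. Among the compounds with values here, no two measured compounds differ in a single place, so no step size is known. For the step from compound 2 to compound 3 in this assay nothing beyond the usual scatter is expected, in either direction. Compound 3 is therefore expected to read around 50000 nM, within 20000 nM to 100000 nM, most likely again reported only as a limit.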

Compound 3, half-maximal cytotoxic concentration: "not toxic" (no number reported)
The entry for compound 3 holds no number, so the estimate cannot be set against anything.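

Within the data shown here, compound 2 and compound 3 both carry the entry "not toxic" without a number, and no step between them can be read. The compounds shown leave open at what concentration any of them would harm the cells in this assay, since the only figure given is a limit: the limit of > 50000 nM in this assay, at which 1 of the 3 values shown sits.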